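Changing the Carbonyl Cap from Methyl to Benzyloxy

A few compounds are considered here, and "the series" means these few. Any claim that something is new, unique, unknown or untested is made for them only; others in the source may bear on it.

Compound 3 `CC(=O)N1CCC(CN(C2Cc3cc(C#N)ccc3N(Cc3cncn3C)C2)S(=O)(=O)c2ccccn2)CC1` is one of three close analogues that differ only in the group carried on a carbonyl carbon whose other neighbour is an amide-type nitrogen in a ring. In an ADME assay on Caco-2 cells (Homo sapiens) for permeability, in the apical to basolateral direction (on this read-out lower numbers stand for lower permeability and higher numbers for higher permeability), compound 3 gives 0.5 10^-6 cm/s. Compound 1 `Cn1cncc1CN1CC(N(CC2CCN(C(=O)C(C)(C)C)CC2)S(=O)(=O)c2ccccn2)Cc2cc(C#N)ccc21` gives 0.5 10^-6 cm/s and compound 2 `CCC(=O)N1CCC(CN(C2Cc3cc(C#N)ccc3N(Cc3cncn3C)C2)S(=O)(=O)c2ccccn2)CC1` gives 0.5 10^-6 cm/s, so compound 3 stands level with both of them. The steps among the three were flat: no change at the digits printed from compound 1 to compound 2 (within the scatter), no change at the digits printed from compound 1 to compound 3 (within the scatter) and no change at the digits printed from compound 2 to compound 3 (within the scatter).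

Compound 4 `Cn1cncc1CN1CC(N(CC2CCN(C(=O)OCc3ccccc3)CC2)S(=O)(=O)c2ccccn2)Cc2cc(C#N)ccc21` is the next member of the series. Its difference from compound 3 is benzyloxy in place of methyl on a carbonyl carbon. All three measured steps bear on this change, since each of them alters the group on the same carbonyl carbon, and each stayed within the scatter. Within the data shown here, the entering group is larger than anything tried at this position so far, but the data give no sign that the read-out responds to what sits there. One therefore expects no step beyond the scatter in this assay, in neither direction.

For compound 4 the expected value in this assay is 0.5 10^-6 cm/s, with a range from 0.25 10^-6 cm/s to 1.2 10^-6 cm/s. This corresponds to an expected step of no change at the digits printed from compound 3 to compound 4 (within the scatter).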

Compound 4, apparent permeability: 1 10^-6 cm/s
Compound 4: middle estimate off by 2.0-fold (0.30 log units), on the low side; low and high end bracket the measured number.
By their numbers in this assay, from the lowest: compounds 1, 2, 3 and 4 (each within the scatter of the next).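

In this assay the group on a carbonyl carbon whose other neighbour is an amide-type nitrogen in a ring can also be benzyloxy, which brings in a six-membered aromatic ring of carbon only and a hydrogen-bond acceptor, and the steps read a 2.0-fold higher number from compound 3 to compound 4 (0.30 log units; within the scatter) and a 2.0-fold higher number from compound 2 to compound 4 (0.30 log units; within the scatter) and a 2.0-fold higher number from compound 1 to compound 4 (0.30 log units; within the scatter) for the three earlier caps. Methyl, ethyl and tert-butyl had tested this place only with saturated carbon groups, whereas compound 4 is the first here with a ring and an oxygen on that carbonyl carbon, and even this much bigger change does not take the read-out beyond the scatter, so the printed difference cannot be read as a real effect of benzyloxy. Nothing measured alongside these numbers offers an account of how this position behaves.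

As far as these compounds go, whether an aminomethyl group or a carboxylic acid on this carbonyl carbon would move the read-out beyond the scatter remains open. So does whether phenyl bound directly to the carbonyl carbon would match benzyloxy, which would separate the part played by the ring from that of the oxygen.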